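Working notes on the series: compound 2 to compound 3

The source may hold more compounds than are shown below. What is called first, only, known or untested is meant among the compounds shown, and "the series" means these compounds.

Measured so far, in a functional assay on MCF7 cells (Homo sapiens) for cytotoxicity, read by neutral red uptake, with a stated time of 3 days; on this read-out higher numbers stand for weaker inhibition and lower numbers for stronger inhibition:
compound 1 `Nc1ccc(-c2cc(=O)c3c(N)c(F)c(Cl)c(F)c3o2)cc1F`: 210 nM
compound 2 `CCC(=O)OCc1c(F)c(N)c2c(=O)cc(-c3ccc(N)c(F)c3)oc2c1F`: 130 nM

Within the data shown here, compound 2 stands at the lowest of the two numbers, with compound 1 nearest; the single measured step, a 1.6-fold lower number from compound 1 to compound 2 (0.21 log units; within the scatter), does not separate them beyond the scatter.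

Compound 3 `CN(C)Cc1c(F)c(N)c2c(=O)cc(-c3ccc(N)c(F)c3)oc2c1F` differs from compound 2 by dimethylamino in place of propanoyloxy on a saturated chain carbon bound to an aromatic carbon. Among the measured compounds shown here, the one step available bears on it only loosely: it brought in the (propanoyloxy)methyl group that is now altered, and it was itself within the scatter. With the propanoyloxy part giving way to dimethylamino on the saturated chain carbon, nothing measured argues for a step beyond the scatter in this assay in either direction. Compound 3 is therefore expected to sit near compound 2, at an estimated 150 nM (range 60 nM to 400 nM), the expected step being a 1.2-fold higher number from compound 2 to compound 3 (0.06 log units; within the scatter).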

Compound 3, half-maximal inhibitory concentration: 72 nM
For compound 3 the middle estimate is 2.1-fold (0.32 log units) above the measured one; measured number inside the range.
By their numbers in this assay, from the lowest: compounds 3, 2 and 1 (each within the scatter of the next, the first and the last beyond it).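

In this assay, the step of dimethylamino in place of propanoyloxy on the saturated chain carbon is a 1.8-fold lower number from compound 2 to compound 3 (0.26 log units; within the scatter) and so does not separate these two groups. Measured against chloro on the aromatic carbon, however, (dimethylamino)methyl gives a 2.9-fold lower number from compound 1 to compound 3 (0.46 log units; beyond the scatter) and is the only replacement shown at this place whose step from chloro clears the scatter, if modestly, so this carbon tolerates a basic-free reading of neither more nor less than a small gain. Nothing available accounts for these numbers.

The compounds shown carry only chloro, (propanoyloxy)methyl and (dimethylamino)methyl at this place. From the compounds shown here alone, how a primary amine, a morpholine or a carboxylic acid on the same saturated chain carbon would read remains open, as does a longer chain in its place.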